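A few compounds are considered here, and "the series" means these few. Any claim that something is new, unique, unknown or untested is made for them only; others in the source may bear on it.

Measured so far:
compound 1 `Cc1cc(-c2cccc(C#N)c2)cc(C)c1Nc1ccnc(Nc2ccc(C#N)cc2)n1` — in an ADME assay on MT4 cells (Homo sapiens) for cytotoxicity, read by MTT assay, with a stated time of 4 days (a higher number here means that more compound is tolerated, a lower number that less compound is tolerated), compound 1 gives 920 nM
compound 2 `Cc1cc(-c2ccccc2Cl)cc(C)c1Nc1ccnc(Nc2ccc(C#N)cc2)n1` — in this assay compound 2 gives 3990 nM

Among the measured compounds shown here, compound 2 holds the higher of the two numbers; the only measured step is a 4.3-fold higher number from compound 1 to compound 2 (0.64 log units; beyond the scatter), a swap of the whole pendant aryl. Compound 3 `Cc1cccc(-c2cc(C)c(Nc3ccnc(Nc4ccc(C#N)cc4)n3)c(C)c2)c1` carries the change (3-methylphenyl in place of 2-chlorophenyl on an aromatic carbon). For the measured compounds named here, no measured step isolates a chlorine-to-methyl exchange, and compound 1's 3-cyanophenyl is the nearest comparator for a meta-substituted ring, so the expectation for compound 3 is uncertain: a step of at most modest size in this assay, probably back toward compound 1. Compound 3 is estimated at 2500 nM (range 800 nM to 8000 nM), which means an expected 1.6-fold lower number from compound 2 to compound 3 (0.20 log units; within the scatter).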

Compound 3, half-maximal cytotoxic concentration: 3670 nM
Compound 3: middle estimate off by 1.5-fold (0.17 log units), on the low side; the measured number falls inside the stated range.
By their numbers in this assay, from the lowest: compound 1; then compounds 3 and 2 (each within the scatter of the next).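

In this assay, 3-methylphenyl in place of 2-chlorophenyl gives no separation (a 1.1-fold lower number from compound 2 to compound 3 (0.04 log units; within the scatter)), so these two rings cannot be told apart here. Methyl in place of cyano (a 4.0-fold higher number from compound 1 to compound 3 (0.60 log units; beyond the scatter)) is the first step that changes only the substituent on the pendant ring, and it sets compound 1 apart from both other compounds. Nothing available explains that difference.

As far as these compounds go, whether an amine or a carboxylic acid on this ring would track the nitrile or the methyl remains open. Also open, from the compounds shown here alone, is whether chlorine and methyl would still match if both stood at one ring position.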